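This account rests on a few compounds, and the source may have more. Where it says the series, first, only, none or still open, it means among the compounds named here.

Measured so far in an assay on CHO cells for displacement of a labelled ligand from adenosine receptor A3 (Homo sapiens), read by scintillation counting, with a stated time of 60 min; on this read-out higher numbers stand for weaker inhibition and lower numbers for stronger inhibition:
Compound 1 `O=C(CCCc1ccccc1)Nc1nc2ccccc2c(=O)s1` gives only a limit, > 1000 nM.
Compound 2 `O=C(CCCc1ccc(Cl)c(Cl)c1)Nc1nc2ccccc2c(=O)s1` gives only a limit, > 1000 nM.
Compound 3 `O=C(CCCc1ccccc1)Nc1nc2cc(Cl)ccc2c(=O)s1` gives 91.6 nM.

Compound 1 therefore stands at the edge of what the method reports, not at a number; (the limit of > 1000 nM in this assay, at which 2 of the 3 values shown sit). Compound 4 `Cc1ccc2nc(NC(=O)CCCc3ccccc3)sc(=O)c2c1` differs from compound 1 by methyl in place of hydrogen on an aromatic carbon, on an aromatic carbon of a six-membered aromatic ring of carbon only, part of a fused system of two rings, meta to a fused ring and para to a fused ring. Two measured steps start from compound 1. The step that the two limits leave unreadable from compound 1 to compound 2, a swap of the ring three bonds along the chain from a carbonyl carbon, stays unreadable: both values are limits. The step of an at least 10-fold lower number from compound 1 to compound 3 (1.03 log units; beyond the scatter) is also a change on an aromatic carbon, and it is large. Methyl is a different group from chloro, so a smaller gain is expected in this assay. Compound 4 is expected to give 500 nM, between 100 nM and 3000 nM. That corresponds to an expected step of an at least 2.0-fold lower number from compound 1 to compound 4 (0.30 log units; that floor lies within the scatter).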

Compound 4, inhibition constant: 147 nM
Beside the measured number, compound 4's estimate is 3.4-fold (0.53 log units) above it; the range from low to high includes it.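

In this assay, methyl in place of hydrogen on an aromatic carbon of the six-membered ring of carbon only gives an at least 6.8-fold lower number from compound 1 to compound 4 (0.83 log units; beyond the scatter). The earlier gain on this ring, an at least 10-fold lower number from compound 1 to compound 3 (1.03 log units; beyond the scatter), came with chloro, so the new result shows that a gain on this ring is not tied to chloro: a single added carbon, with no hydrogen-bond donors or acceptors, is enough at this position. Compound 1 stands at a limit and not at a number, so the full size of the step stays unknown: the limit of > 1000 nM in this assay, at which 2 of the 4 values shown sit.

What the compounds shown leave open is how an ethyl group, a methoxy group or an amine on this same aromatic carbon would read. Also open, from the compounds shown here alone, is whether methyl and chloro together on the shared core would give more than either one alone.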